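Fluoromethyl for methoxymethyl on the shared core

A few compounds are considered here, and "the series" means these few. Any claim that something is new, unique, unknown or untested is made for them only; others in the source may bear on it.

Compound 1 `COC[C@H](C)[C@H](C)C(c1ccc(O)c(OC)c1)c1ccc(O)c(OC)c1`, compound 2 `COC[C@H](C(C)C)C(c1ccc(O)c(OC)c1)c1ccc(O)c(OC)c1` and compound 3 `COC[C@@H](C(C)C)C(c1ccc(O)c(OC)c1)c1ccc(O)c(OC)c1` keep the shared core and differ only in the branched chain on the saturated chain carbon bound to two aromatic carbons. In a functional assay on HL-60 cells (Homo sapiens) for cytotoxicity, read by WST assay, with a stated time of 48 h (a lower number here means a stronger inhibitor, a higher number a weaker inhibitor), compound 1 gives 82000 nM, compound 2 gives 72000 nM and compound 3 gives 54000 nM. Compound 2 stands second highest of the three numbers, nearest to compound 1 and furthest from compound 3. The measured steps are small: a 1.1-fold lower number from compound 1 to compound 2 (0.06 log units; within the scatter), a 1.5-fold lower number from compound 1 to compound 3 (0.18 log units; within the scatter), and a 1.3-fold lower number from compound 2 to compound 3 (0.12 log units; within the scatter), the last one a pure configuration step because of the fact that compounds 2 and 3 differ only in the configuration as drawn. None of them is beyond the scatter.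

Compound 4 `COc1cc(C(c2ccc(O)c(OC)c2)[C@@H](C)[C@H](C)CF)ccc1O` is the next compound for this assay. Relative to compound 2 the change is 2-(fluoromethyl)-1-methylpropyl in place of 1-(methoxymethyl)-2-methylpropyl on a saturated chain carbon bound to two aromatic carbons. Within the data shown here, no measured step exchanges the methoxymethyl for a fluoromethyl, so that part of the change is untested here. The shift of the branching pattern has a precedent in a 1.1-fold lower number from compound 1 to compound 2 (0.06 log units; within the scatter), which stayed within the scatter. On this basis no step beyond the scatter is expected for compound 4 in this assay, and the expected step is a 1.0-fold lower number from compound 2 to compound 4 (0.01 log units; within the scatter). The estimate for compound 4 in this assay is 70000 nM, with an expected range from 30000 nM to 160000 nM.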

Compound 4, half-maximal inhibitory concentration: 32000 nM
Compound 4: middle estimate off by 2.2-fold (0.34 log units), on the high side; the measured number falls inside the stated range.
By their numbers in this assay, from the lowest: compounds 4, 3, 2 and 1 (each within the scatter of the next, the first and the last beyond it).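

In this assay, among these compounds, the 2-(fluoromethyl)-1-methylpropyl chain on a saturated chain carbon bound to two aromatic carbons gives the first steps that lie beyond the scatter: a 2.3-fold lower number from compound 2 to compound 4 (0.35 log units; beyond the scatter) and a 2.6-fold lower number from compound 1 to compound 4 (0.41 log units; beyond the scatter), both modest. The second of these is the narrower comparison, with 1-(fluoromethyl)ethyl in place of 1-(methoxymethyl)ethyl on a saturated chain carbon bound to two saturated chain carbons, so this position responds to the exchange of the chain end, whereas the branching and configuration steps among compounds 1, 2 and 3 stayed within the scatter. The response is limited, however, as a 1.7-fold lower number from compound 3 to compound 4 (0.23 log units; within the scatter) stays within the scatter, so compound 4 is not clearly separated from compound 3.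

Nothing measured here explains why the fluoromethyl chain end gives these steps. The compounds shown leave open whether a hydroxymethyl, an aminomethyl or a trifluoromethyl group at the same chain end would move the number further, and whether the other configurations of the 2-(fluoromethyl)-1-methylpropyl chain would behave like compound 4.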